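Methyl on the oxanyl amine nitrogen: permeability notes

The source may hold more compounds than are shown below. What is called first, only, known or untested is meant among the compounds shown, and "the series" means these compounds.

Measured so far in an ADME assay for permeability, using PAMPA, with a stated time of 4 h, at pH 7.4; on this read-out lower numbers stand for lower permeability and higher numbers for higher permeability:
- compound 1 `NC/C=C\CN(C[C@H]1Cc2ncccc2CN1)[C@H]1CCCc2cccnc21` gives 68 nm/s
- compound 2 `c1cnc2c(c1)CN[C@@H](CN(CCCCNC1CCOCC1)[C@H]1CCCc3cccnc31)C2` gives 8 nm/s

Among the measured compounds shown here, compound 2 holds the lower of the two numbers, and compound 1 is its only measured neighbour. Compound 3 `CN(CCCCN(C[C@H]1Cc2ncccc2CN1)[C@H]1CCCc2cccnc21)C1CCOCC1` differs from compound 2 in one place (methyl in place of hydrogen on an amine nitrogen): methyl in place of hydrogen on an amine nitrogen, so that (oxan-4-yl)amino becomes methyl(oxan-4-yl)amino.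

For the measured compounds named here, only one measured step bears on this, and only indirectly (an 8.5-fold lower number from compound 1 to compound 2 (0.93 log units; beyond the scatter)). It lies beyond the scatter, but it exchanges a whole side chain, 3-((oxan-4-yl)amino)propyl in place of 3-aminoprop-1-en-1-yl. Going by the values given here, no measured pair isolates methyl on this nitrogen, so that step serves only as a loose guide to how far the numbers can move.

A small upward step in this assay is expected, close to the scatter and well short of the measured one, although the data give no direct evidence of its direction. The estimated step is a 1.6-fold higher number from compound 2 to compound 3 (0.21 log units; within the scatter) on this reading. Compound 3 is expected at 13 nm/s (range 6 nm/s to 30 nm/s).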

Compound 3, apparent permeability: 490 nm/s
For compound 3 the middle estimate is 38-fold (1.58 log units) below the measured one; the whole stated range lies below it.
By their numbers in this assay, from the lowest: compound 2; then compound 1; then compound 3.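

In this assay the single added methyl on the amine nitrogen, turning (oxan-4-yl)amino into methyl(oxan-4-yl)amino, gives a 61-fold higher number from compound 2 to compound 3 (1.79 log units; beyond the scatter) and so moves the number further than the exchange of the whole side chain, which gave an 8.5-fold lower number from compound 1 to compound 2 (0.93 log units; beyond the scatter) in the other direction. The longer side chain therefore does not set a low number on its own: with the methyl in place, the group of 11 heavy atoms in place of the group of 4 heavy atoms gives a 7.2-fold higher number from compound 1 to compound 3 (0.86 log units; beyond the scatter) and thus reverses the direction seen for the same exchange without the methyl. Nothing available here accounts for so large a move from a single added carbon on this nitrogen.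

As far as these compounds go, whether the methyl is special at this nitrogen stays open, as an ethyl or an acetyl group on the same atom would be needed to tell. Also open, from the compounds shown here alone, is whether a methyl on the primary amine of compound 1 would shift the number in the same direction.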